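Metabolic stability after an aryl swap on the oxazole core

This account rests on a few compounds, and the source may have more. Where it says the series, first, only, none or still open, it means among the compounds named here.

Measured compounds:
compound 1, `Cc1ccccc1-c1nc(CN2CCC(C(=O)NCCCN3CC(C)(C)CC(C)(C)C3)CC2)c(C)o1` — 0.095 h
compound 2, `Cc1oc(-c2ccc(Cl)cc2)nc1CN1CCC(C(=O)NCCCN2C[C@H](C)C[C@H](C)C2)CC1` — > 0.5 h

Of the compounds shown here, two have been tested in an ADME assay on microsomes from liver (Rattus norvegicus) for metabolic stability, read by LC-MS, using NADPH, at 37 degrees C; on this read-out higher numbers stand for a longer-lived compound and lower numbers for a shorter-lived compound. Compound 1, `Cc1ccccc1-c1nc(CN2CCC(C(=O)NCCCN3CC(C)(C)CC(C)(C)C3)CC2)c(C)o1`, is short-lived, giving 0.095 h. Compound 2, `Cc1oc(-c2ccc(Cl)cc2)nc1CN1CCC(C(=O)NCCCN2C[C@H](C)C[C@H](C)C2)CC1`, is reported only as a limit of the assay, > 0.5 h; the measurement stopped at the limit of > 0.5 h in this assay, at which 1 of the 2 values shown sits, so no exact number stands for compound 2. The two compounds differ in more than one place, so their values can only be compared side by side, and they show that compound 2 outlasts compound 1 in this assay.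

Compound 3, `COc1cccc(C)c1-c1nc(CN2CCC(C(=O)NCCCN3C[C@H](C)C[C@H](C)C3)CC2)c(C)o1`, is not yet measured. It comes from compound 2 by the change (2-methoxy-6-methylphenyl in place of 4-chlorophenyl on an aromatic carbon). No measured step of this kind is shown, so the size of the effect is open. The expectation is a step downward, from compound 2 to compound 3 of an at least 1.6-fold lower number from compound 2 to compound 3 (0.22 log units; that floor lies within the scatter), extending beyond the usual scatter. Compound 3 is therefore estimated to give 0.3 h, within a range from 0.1 h to 0.6 h.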

Compound 3, half-life: 0.0767 h
For compound 3 the middle estimate is 3.9-fold (0.59 log units) above the measured one; the whole stated range lies above it.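

In this assay, putting 2-methoxy-6-methylphenyl in place of 4-chlorophenyl on an aromatic carbon of the shared core, with the rest of the molecule unchanged, gives an at least 6.5-fold lower number from compound 2 to compound 3 (0.81 log units; beyond the scatter). This is the first step shown between compounds that differ in one place, so it shows that the aryl group at this position can by itself move the half-life, which the side-by-side view of compound 1 and compound 2 could not separate from their other differences. The step is only a floor and the true drop may be larger, because the value for compound 2 is a limit of the assay and not a number: the limit of > 0.5 h in this assay, at which 1 of the 3 values shown sits.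

The compounds shown leave open which part of the new group goes with the drop, the methoxy or the methyl, and a plain 2-methoxyphenyl at the same place would be the simplest group to separate the two. They also leave open how a pyridine ring in that place, or a 4-chlorophenyl carrying a methoxy group as well, would read in this assay.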